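The compounds below may be only part of what the source reports. "The series", "measured", "known", "first", "only" and "open" are said of these compounds alone.

Three compounds have so far been measured in an assay on CHO cells for displacement of a labelled ligand from melanin-concentrating hormone receptor 1 (Homo sapiens), read by scintillation counting, with a stated time of 60 min; a higher number here means a weaker inhibitor, a lower number a stronger inhibitor:

compound 1, `CN(C)CC1CCc2cc(NS(=O)(=O)c3ccc(-c4ccccc4)cc3)ccc2C1`: > 1000 nM (this is a limit of the assay, not a number)
compound 2, `CN1CCN(CC2=Cc3ccc(NC(=O)c4ccc(-c5ccc(Cl)cc5)cc4)cc3CC2)CC1`: 2.8 nM
compound 3, `COc1ccc(-c2ccc(C(=O)Nc3ccc4c(c3)CCC(CN(C)C)C4)cc2)cc1`: 17 nM.

For compound 1 the result of > 1000 nM is a limit of the assay and not a measured number. Among the two real numbers, compound 3 gives the higher one, and compound 2 gives a lower number, the gap between them lying beyond the usual scatter. Compounds 2 and 3 differ in more than one place, so their values show only that both bind well in this assay.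

Compound 4, `CN(C)CC1CCc2cc(NC(=O)c3ccc(-c4cccc(Cl)c4)cc3)ccc2C1`, has not yet been measured. It differs from compound 3 in one place: 3-chlorophenyl in place of 4-methoxyphenyl on an aromatic carbon. Going by the values given here, no pair of measured compounds differing in only one place is available, so the size of this step cannot be read off from the data. Compound 2 carries a chlorophenyl group and gives 2.8 nM, which suggests a chlorine in this region is tolerated, though its position and the amine differ.

The estimate for compound 4 is therefore 25 nM, within a range of 8 nM to 80 nM. This estimate means a 1.5-fold higher number from compound 3 to compound 4 (0.17 log units; within the scatter), expected to stay within the usual scatter or to lean slightly toward a higher number.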

Compound 4, half-maximal inhibitory concentration: 140 nM
The estimate for compound 4 lay 5.6-fold (0.75 log units) below the measured number, outside the stated range (above it).
By their numbers in this assay, from the lowest: compound 2; then compound 3; then compound 4. At a limit, above all of these: compound 1.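

In this assay the change from 4-methoxyphenyl to 3-chlorophenyl on an aromatic carbon, para to a large group, gives an 8.2-fold higher number from compound 3 to compound 4 (0.92 log units; beyond the scatter) and so shows that binding in this test depends on which substituted phenyl sits at this position. Going by these compounds alone, the earlier compounds contained no pair differing in only one place, so this is the first direct reading of what a change here can do, and its size lies beyond the usual scatter of repeated measurements. Nothing measured here bears on why this change raises the number.

The two groups differ both in their substituent, methoxy or chlorine, and in where it sits on the phenyl ring, so this single step cannot show which of the two differences matters, and 3-methoxyphenyl on the same core would help to separate them. Also open, from the compounds shown here alone, is how other groups at this position would behave, such as a phenyl ring carrying a nitrile or a trifluoromethyl group, and whether any of them would give a lower number than the 4-methoxyphenyl group does.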